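The source may hold more compounds than are shown below. What is called first, only, known or untested is meant among the compounds shown, and "the series" means these compounds.

Measured compounds:
- Compound 1 `COc1cc2ncnc(Nc3ccc(F)c(Br)c3)c2cc1OCCCCC(=O)Nc1ccc(S(N)(=O)=O)cc1`, which in a functional assay on A-431 cells (Homo sapiens) for antiproliferative activity, read by MTT assay, with a stated time of 72 h (on this read-out higher numbers stand for weaker inhibition and lower numbers for stronger inhibition), gives 8020 nM
- Compound 2 `COc1cc2ncnc(Nc3cccc(Cl)c3F)c2cc1OCCCCC(=O)Nc1ccc(S(N)(=O)=O)cc1`, which in this assay gives 5560 nM
- Compound 3 `COc1ccccc1Nc1ncnc2cc(OC)c(OCCCCC(=O)Nc3ccc(S(N)(=O)=O)cc3)cc12`, which in this assay gives 24200 nM

All three share the same core and the same long chain ending in the sulfonamide; they differ only in the group attached to the nitrogen on the aromatic ring. Compound 3 stands at the top of the numbers, meaning it is the weakest inhibitor of the three: against compound 1 the step is a 3.0-fold higher number from compound 1 to compound 3 (0.48 log units; beyond the scatter), and against compound 2 it is a 4.4-fold higher number from compound 2 to compound 3 (0.64 log units; beyond the scatter). The step between the two halogenated compounds, a 1.4-fold lower number from compound 1 to compound 2 (0.16 log units; within the scatter), stays within the scatter.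

Compound 4 `CCc1ccc(Nc2ncnc3cc(OC)c(OCCCCC(=O)Nc4ccc(S(N)(=O)=O)cc4)cc23)cc1` takes the same core and chain and differs from compound 3 by 4-ethylphenyl in place of 2-methoxyphenyl on a nitrogen on an aromatic ring. For the measured compounds named here, no measured step exchanges exactly these two groups. Going by the values given here, the steps that bear on it are the two that lead into compound 3, a 3.0-fold higher number from compound 1 to compound 3 (0.48 log units; beyond the scatter) and a 4.4-fold higher number from compound 2 to compound 3 (0.64 log units; beyond the scatter), which show that swapping the group on this nitrogen can move the number by a modest amount and that the 2-methoxyphenyl group sits at the weak end. Whether a 4-ethylphenyl group, which carries no halogen, recovers part of that loss is not settled by these data. The expected step is a 1.9-fold lower number from compound 3 to compound 4 (0.27 log units; within the scatter), a modest gain at best. Compound 4 is therefore estimated at 13000 nM, with a range from 4500 nM to 40000 nM.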

Compound 4, half-maximal inhibitory concentration: 7220 nM
For compound 4 the middle estimate is 1.8-fold (0.26 log units) above the measured one; the range from low to high includes it.
By their numbers in this assay, from the lowest: compounds 2, 4 and 1 (each within the scatter of the next); then compound 3.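

In this assay, the change on this nitrogen from 2-methoxyphenyl to 4-ethylphenyl gives a 3.4-fold lower number from compound 3 to compound 4 (0.53 log units; beyond the scatter), so a ring carrying no halogen can also sit clear of the weak end of this small set. Compound 4 cannot be told apart from either halogenated compound, with a 1.3-fold higher number from compound 2 to compound 4 (0.11 log units; within the scatter) and a 1.1-fold lower number from compound 1 to compound 4 (0.05 log units; within the scatter); among the groups shown, a halogen is therefore not needed to reach this level, and compound 3 alone stands apart. The two exchanged groups have the same number of heavy atoms, with one oxygen leaving and only carbon entering, but nothing on hand explains the step.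

The compounds shown leave open whether the step follows from the methoxy group itself or from where it sits on the ring, a question that 4-methoxyphenyl and 2-ethylphenyl groups on this nitrogen could separate. Also open, as far as these compounds go, are what an amine or a carboxylic acid on this ring would do, and whether a shorter or longer chain ending in the sulfonamide would shift these numbers alike.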